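The source may report more compounds than this note shows. Statements on the series, on what has been measured and on what is new or still open speak of the compounds shown alone.

In a functional assay on FaDu cells (Homo sapiens) for cytotoxicity, read by MTT assay, with a stated time of 72 h (on this read-out higher numbers stand for lower toxicity in this test and lower numbers for higher toxicity in this test), compound 1 `COc1ccc(NC(=O)C(=O)c2cn(C(C)C)c3ccccc23)cc1` gives 181 nM and compound 2 `COc1nsc(NC(=O)C(=O)c2cn(C(C)C)c3ccccc23)n1` gives 10400 nM as the higher of the two numbers. Compound 3 `COc1nc(NC(=O)C(=O)c2cn(C(C)C)c3ccccc23)ns1` holds the same atoms as compound 2, joined differently: a group of 7 heavy atoms (3 carbon, 2 nitrogen, 1 oxygen, 1 sulfur; one five-membered aromatic ring with 3 hetero atoms) in place of a group of 7 heavy atoms (3 carbon, 2 nitrogen, 1 oxygen, 1 sulfur; one five-membered aromatic ring with 3 hetero atoms), on an amide-type nitrogen is the change, on an amide-type nitrogen. For the measured compounds named here, the only measured step of a 57-fold higher number from compound 1 to compound 2 (1.76 log units; beyond the scatter) is large and beyond the scatter, but it replaced 4-methoxyphenyl, a change of another kind, so it gives no direction here and only widens the range. No shift beyond the scatter is expected, and a 1.3-fold lower number from compound 2 to compound 3 (0.11 log units; within the scatter) is the estimated step. In this assay compound 3 is estimated at 8000 nM with a range from 1500 nM to 40000 nM around it.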

Compound 3, concentration lethal to 50% of the cells: > 10000 nM
Compound 3: only a limit was reported; the forecaster's own chance of this, stated with the estimate: 10%; middle value at least 1.2-fold (0.09 log units) away from the limit.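

For compound 3, only a limit is reported in this assay: the limit of > 10000 nM in this assay, at which 1 of the 3 values shown sits.

Placing this second five-membered aromatic ring with 3 hetero atoms on the amide-type nitrogen in place of 4-methoxyphenyl still gives an at least 55-fold higher number from compound 1 to compound 3 (1.74 log units; beyond the scatter), so the large rise seen with compound 2 is not confined to one arrangement of ring atoms. The step between the two ring arrangements cannot be read, so they cannot be ranked.

On these data alone, whether a pyridyl ring on this nitrogen would read nearer compound 1 or compound 3 remains open. So does the effect of an amine in place of the methoxy group.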